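From nitro to fluoro: the expected size of one change

The source may hold more compounds than are shown below. What is called first, only, known or untested is meant among the compounds shown, and "the series" means these compounds.

Of the compounds shown here, two have so far been tested in a functional assay on Calu-3 cells (Homo sapiens) for cytotoxicity, read by WST assay, with a stated time of 72 h; on this read-out lower numbers stand for stronger inhibition and higher numbers for weaker inhibition. Compound 1, `COc1ccc(-c2cc(-c3cc4ccccc4n3C)no2)cc1`, gives only a limit of the assay in this assay, reading > 100000 nM. That result for compound 1 is the limit of > 100000 nM in this assay, at which 1 of the 2 values shown sits. Compound 2, `O=[N+]([O-])c1ccc(-c2cc(-c3ccc4[nH]ccc4c3)on2)cc1`, reads 25800 nM in this assay. Among the compounds with values here, compound 2 therefore stands as the only compound with a numbered result, the single fixed point among the two values shown. Within the data shown here, no pair of measured compounds differs in just one place, so no measured step is at hand to guide the next move.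

Compound 3, `Fc1ccc(-c2cc(-c3ccc4[nH]ccc4c3)on2)cc1`, is the next compound, and it differs from compound 2 in one place: fluoro in place of nitro on an aromatic carbon. A fluoro in place of a nitro is a change of one group at one spot of the shared core. Among the measured compounds shown here, with no measured step to lean on, the shift from compound 2 to compound 3 in this assay is expected to be small, a slight weakening at most, as a 1.6-fold higher number from compound 2 to compound 3 (0.19 log units; within the scatter). For compound 3 the estimate in this assay is 40000 nM, with a range from 12000 nM to 130000 nM.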

Compound 3, half-maximal inhibitory concentration: 16800 nM
For compound 3 the middle estimate is 2.4-fold (0.38 log units) above the measured one; the measured number falls inside the stated range.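

In this assay, putting fluoro in place of nitro on an aromatic carbon, para to a large group, gives a 1.5-fold lower number from compound 2 to compound 3 (0.19 log units; within the scatter), the first measured step among these compounds. The two groups are quite unlike in what is counted for them: nitro brings 3 heavy atoms and 2 hydrogen-bond acceptors, while fluoro brings 1 heavy atom and no hydrogen-bond acceptors, yet at this position the read-out does not tell them apart. No measurement at hand bears on why these two groups read alike.

Going by these compounds, whether an amine or a carboxylic acid at this same spot would also read alike stays open, and so does whether a step of this size would hold at any other place on the shared core. Within the data shown here, compound 1 stands at a limit of the assay, > 100000 nM, and it differs from compound 3 in more than one place, so it offers no single step to set beside this one.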